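Series notes: from compound 3 to compound 4

This account rests on a few compounds, and the source may have more. Where it says the series, first, only, none or still open, it means among the compounds named here.

Three compounds have been run in an ADME assay on microsomes from liver (Homo sapiens) for metabolic stability; a higher number here means that the compound lasts longer, a lower number that the compound disappears faster. For the measured compounds named here, compound 1 `O=C1NC(=O)/C(=C/C(c2ccc(-c3ccc4cccc(F)c4c3)[nH]c2=O)C2CC2)O1` gives 1.98 h; compound 2 `O=C1NC(=O)/C(=C/C(c2ccc(-c3ccc4cccc(F)c4c3)[nH]c2=O)C2CCCCC2)O1` gives 1.09 h, and the one measured step, a 1.8-fold lower number from compound 1 to compound 2 (0.26 log units; within the scatter), lies within the scatter. Compound 3 `CC(C)C(c1ccc(-c2ccc3cccc(F)c3c2)[nH]c1=O)C1C(=O)NC(=O)N1C` gives 0.375 h, the lowest of the three numbers, below compound 2 and compound 1 by margins beyond the scatter. Compound 4 `CC(C)C(CC1NC(=O)NC1=O)c1ccc(-c2ccc3cccc(F)c3c2)[nH]c1=O` differs from compound 3 by (2,5-dioxoimidazolidin-4-yl)methyl in place of 3-methyl-2,5-dioxoimidazolidin-4-yl on a saturated chain carbon bound to an aromatic carbon and a saturated chain carbon. Going by the values given here, no measured step touches this change: the step from compound 1 to compound 2 alters the ring on a different chain carbon, and none alters the five-membered ring or its attachment. The expectation is therefore a step of no defined direction, a 1.2-fold higher number from compound 3 to compound 4 (0.08 log units; within the scatter), within the scatter. Compound 4 is estimated at 0.45 h, range 0.18 h to 1.2 h.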

Compound 4, half-life: 1.59 h
Beside the measured number, compound 4's estimate is 3.5-fold (0.55 log units) below it; the whole stated range lies below it.
By their numbers in this assay, from the lowest: compound 3; then compounds 2, 4 and 1 (each within the scatter of the next).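

At this saturated chain carbon, the way the five-membered ring is joined matters: in this assay, (2,5-dioxoimidazolidin-4-yl)methyl in place of 3-methyl-2,5-dioxoimidazolidin-4-yl gives a 4.2-fold higher number from compound 3 to compound 4 (0.63 log units; beyond the scatter), with the same atoms throughout. The earlier compounds shown here included no change to this ring or its attachment. Nothing measured here accounts for the step.

The compounds shown do not separate the loss of the 3-methyl from the addition of the methyl link. As far as these compounds go, how a carboxylic acid or an amine would behave on this carbon also remains open.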